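Trimming Ethyl to Methyl on Compound 2

This account rests on a few compounds, and the source may have more. Where it says the series, first, only, none or still open, it means among the compounds named here.

Among the compounds with values here, in a functional assay on HepG2 cells (Homo sapiens) for antiproliferative activity, read by MTT assay, with a stated time of 48 h (a lower number here means a stronger inhibitor, a higher number a weaker inhibitor), compound 2 (`CCc1ccccc1NC(=O)Nc1cccc(CNc2nccnc2Cl)c1`) gives 7860 nM, the only exact number so far. Compound 1 (`CN(C)c1ccc(NC(=O)Nc2cccc(CNc3nccnc3Cl)c2)cc1`) reads > 40000 nM, which is a limit of the assay and not a number.

Compound 3 (`Cc1ccccc1NC(=O)Nc1cccc(CNc2nccnc2Cl)c1`) carries 2-methylphenyl where compound 2 carries 2-ethylphenyl, with hydrogen in place of methyl on a saturated chain carbon bound to an aromatic carbon. Within the data shown here, the one measured step, an at least 5.0-fold lower number from compound 1 to compound 2 (0.70 log units; beyond the scatter), came with 2-ethylphenyl in place of 4-(dimethylamino)phenyl on an amide-type nitrogen. That was a much bigger swap than the present one, so it shows that this group can matter but gives no direct size for the new step.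

In this assay, no change beyond the scatter is expected, and the estimated step is a 1.1-fold higher number from compound 2 to compound 3 (0.06 log units; within the scatter). For compound 3 the estimated value is 9000 nM, with an expected range of 4000 nM to 22000 nM.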

Compound 3, half-maximal inhibitory concentration: 15300 nM
Beside the measured number, compound 3's estimate is 1.7-fold (0.23 log units) below it; the measured number falls inside the stated range.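

In this assay, trimming ethyl to methyl gives a 1.9-fold higher number from compound 2 to compound 3 (0.29 log units; within the scatter), so this first direct test of the position shows that removing one carbon from the chain leaves compound 2 and compound 3 indistinguishable. The 2-methylphenyl group also stays clearly apart from 4-(dimethylamino)phenyl, with an at least 2.6-fold lower number from compound 1 to compound 3 (0.41 log units; beyond the scatter), so that separation does not depend on the ethyl group alone. Compound 1 stands at a limit of the assay and not at a number, so both steps from it give only a minimum size: the limit of > 40000 nM in this assay, at which 1 of the 3 values shown sits.

The compounds shown leave open how the series would respond to a longer chain such as propyl, or to a methoxy group or a chlorine atom in place of the ethyl. They also leave open how a plain phenyl ring, with no such group, would read.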